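This account rests on a few compounds, and the source may have more. Where it says the series, first, only, none or still open, it means among the compounds named here.

In an ADME assay on the whole organism (strain CD-1) for metabolic stability, with Mus musculus as the target, at a dose of 3 mg/kg by the intravenous route (on this read-out lower numbers stand for a shorter-lived compound and higher numbers for a longer-lived compound), two compounds that differ only at one end of a chain have been measured so far. Compound 1 `CC(CCCCOc1ccccc1CN(C)C(=O)c1ccc(-c2ccco2)cc1)C(=O)O` gives 2.8 h, and compound 2 `CN(Cc1ccccc1OCCC[C@@H]1C[C@@H]1C(=O)O)C(=O)c1ccc(-c2ccco2)cc1` gives 2.7 h. Among the compounds with values here, compound 2 therefore stands level with the only other number available, since the step of a 1.0-fold lower number from compound 1 to compound 2 (0.02 log units; within the scatter) lies within the scatter of repeated measurements.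

The change now in question leads to compound 3 `CN(Cc1ccccc1OCCC/C=C/C(=O)O)C(=O)c1ccc(-c2ccco2)cc1`: 2-carboxyethenyl in place of 2-carboxycyclopropyl on a saturated chain carbon, three bonds along the chain from an oxygen on an aromatic ring.

Within the data shown here, only one measured step bears on this change, the swap of 2-carboxypropyl for 2-carboxycyclopropyl at that same place, and its size was a 1.0-fold lower number from compound 1 to compound 2 (0.02 log units; within the scatter). Among the measured compounds shown here, this is thin evidence, and no measured compound carries 2-carboxyethenyl, so the data point to no direction. A shift beyond the scatter is therefore not expected, and the expected step is a 1.1-fold lower number from compound 2 to compound 3 (0.05 log units; within the scatter). For compound 3 the estimated value is 2.4 h, with an expected range from 1.1 h to 4.6 h.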

Compound 3, half-life: 1.9 h
Compound 3: middle estimate off by 1.3-fold (0.10 log units), on the high side, and the stated range covers the measured number.
By their numbers in this assay, from the lowest: compounds 3, 2 and 1 (each within the scatter of the next).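

In this assay, the end of the chain now takes a third form, the open 2-carboxyethenyl group, which has no ring and one more double bond than 2-carboxycyclopropyl. Even so, the steps remain small: a 1.4-fold lower number from compound 2 to compound 3 (0.15 log units; within the scatter) and a 1.5-fold lower number from compound 1 to compound 3 (0.17 log units; within the scatter) are the two new readings. At this place, on a saturated chain carbon three bonds along the chain from an oxygen on an aromatic ring, the half-life therefore does not separate the 2-carboxypropyl, 2-carboxycyclopropyl and 2-carboxyethenyl groups, although the new group gives up the three-membered ring and both defined stereocentres. There is no supporting information that could explain why these numbers stay so close together.

All three groups end in a carboxylic acid, so the compounds shown leave open how the half-life responds when that acid gives way to an ester, a tetrazole or an amine. They also leave open whether a longer chain carrying the same acid would stay within this narrow band.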